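Chain-extended acid analogues in the vitamin D receptor series

The compounds below may be only part of what the source reports. "The series", "measured", "known", "first", "only" and "open" are said of these compounds alone.

Compound 1 `CCC(CC)(c1ccc(OS(=O)(=O)c2ccc(C)cc2)c(C)c1)c1ccc(OCC(O)C(C)(C)C)c(OCC(O)C(C)(C)C)c1` carries a sulfonate ester on one aromatic ring and, in an assay on cells for binding affinity to vitamin D3 receptor (Homo sapiens), read by fluorescence, tested at 1 uM (on this read-out lower numbers stand for less inhibition and higher numbers for more inhibition at the one concentration tested (going by the name of the read-out)), compound 1 gives 43%. Compound 2 `CCC(CC)(c1ccc(OCCCCC(=O)O)c(C)c1)c1ccc(OCC(O)C(C)(C)C)c(OCC(O)C(C)(C)C)c1` replaces that sulfonate ester with an oxygen-linked acid chain, and in this assay compound 2 is reported as "not active" (no number reported), so no single number marks where compound 2 stands; only the absence of measurable inhibition is recorded. For the measured compounds named here, no step between measured compounds is available for the series.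

Compound 3 `CCC(CC)(c1ccc(OCCCCCCC(=O)O)c(C)c1)c1ccc(OCC(O)C(C)(C)C)c(OCC(O)C(C)(C)C)c1` differs from compound 2 in one place: 2-carboxyethyl in place of carboxy on a saturated chain carbon, four bonds along the chain from an oxygen on an aromatic ring. The acid chain is longer by two saturated carbons, the acid itself unchanged. In this assay a step from compound 2 to compound 3 of small size, in either direction, and probably none beyond the scatter, is expected. For compound 3 in this assay an inhibition of 12% is estimated, within a range of 0% to 38%.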

Compound 3, a percentage reported as inhibition, at one concentration (the size of the read-out at that concentration, not a potency): "not active" (no number reported)
For compound 3 the study gives words and no number; the estimate stays without a comparison.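

For the compounds shown here, compound 2 and compound 3 are both reported only in words, as "not active", so no step between them can be read. On these data alone, whether going from carboxy to 2-carboxyethyl changes inhibition in this assay at all stays open. No supporting evidence bears on this result.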